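Benzylcarbamoyl to benzoyl on two triazole cores

This account rests on a few compounds, and the source may have more. Where it says the series, first, only, none or still open, it means among the compounds named here.

Compound 1 `CCCCN(CCCC)Cc1cn(CC(O)COC(=O)NCc2ccccc2)nn1` gives 42% in an assay on nucleic acid for inhibition of Nucleic Acid, read by fluorescence, tested at 100 uM; a lower number here means less inhibition, a higher number more inhibition at the concentration tested (going by the name of the read-out). Compound 3 `CCCCN(CCCC)Cc1cn(CC(O)COC(=O)c2ccccc2)nn1` gives 12%; the step of a number 30 percentage points lower from compound 1 to compound 3 (beyond the scatter) goes with phenyl in place of benzylamino on a carbonyl carbon. Compound 2 `CCOC(=O)C1CCCN(Cc2cn(CC(O)COC(=O)NCc3ccccc3)nn2)C1` gives 47%; its core differs from that of compound 1, and the difference between the two cores is not broken down here. The values of compound 2 and compound 1 lie within the scatter of each other, whereas compound 3 sits well below both. Compound 4 `CCOC(=O)C1CCCN(Cc2cn(CC(O)COC(=O)c3ccccc3)nn2)C1` carries phenyl in place of benzylamino on a carbonyl carbon, the same change as between compound 1 and compound 3, at the same place. For the measured compounds named here, for compound 4 a step of a number 30 percentage points lower from compound 2 to compound 4 (beyond the scatter) is expected, resting on the single earlier step of a number 30 percentage points lower from compound 1 to compound 3 (beyond the scatter). Compound 4 is thus estimated at 17%, with a range from 5% to 32%.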

Compound 4, a percentage reported as inhibition, at one concentration (the size of the read-out at that concentration, not a potency): 6%
Estimate against measurement, compound 4: 11 percentage points above; measured number inside the range.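

In this assay, phenyl in place of benzylamino on a carbonyl carbon goes with a number 41 percentage points lower from compound 2 to compound 4 (beyond the scatter), and the earlier step on the other core is of matching direction and size: the same change on two cores in this assay, a number 30 percentage points lower (beyond the scatter) from compound 1 to compound 3 and a number 41 percentage points lower (beyond the scatter) from compound 2 to compound 4, 11 percentage points apart, within the scatter of two such steps

On these two cores, the change therefore carries over with a comparable result. Two cores cannot show that it will carry to others, and these pairs do not reveal which part of the benzylamino group the numbers follow.

Open, from the compounds shown here alone, is how an anilino group on the same carbonyl carbon would read, or a benzylamino group with a methyl on its nitrogen. A phenethylamino group would test whether a longer chain restores the higher numbers.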